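The source may report more compounds than this note shows. Statements on the series, on what has been measured and on what is new or still open speak of the compounds shown alone.

Compound 3 `CCOC(=O)CCCCCOc1cccc(CN(C(=O)c2ccc(-c3ccc4ccccc4c3)cc2)C(C)C)c1` is the ethyl ester of the series. In an ADME assay on HepG2 cells (Homo sapiens) for cytotoxicity, read by CellTiter-Glo and resazurin assay, with a stated time of 72 h (a lower number here means that less compound is needed, a higher number that more compound is needed for the effect), compound 3 gives > 26000 nM, which is a limit of the assay and not a number. Compound 1 `CC(C)N(Cc1cccc(OCCCCCC(=O)O)c1)C(=O)c1ccc(-c2cccc3ccccc23)cc1`, the free acid with naphthalen-1-yl, gives > 26000 nM in this assay, again a limit. Compound 2 `CC(C)COc1cccc(-c2ccc(C(=O)N(Cc3cccc(OCCCCCC(=O)O)c3)C(C)C)cc2)c1` gives > 26000 nM in this assay, also a limit. The step that the two limits leave unreadable from compound 1 to compound 2 is therefore unreadable. All values shown sit at the limit of > 26000 nM in this assay, at which 3 of the 3 values shown sit, so compound 3 stands exactly where every measured member stands, with no number to place it higher or lower.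

Compound 4 `CCOC(=O)CCCCCOc1cccc(CN(C(=O)c2ccc(-c3cc(OC)cc(OC)c3)cc2)C(C)C)c1` differs from compound 3 by 3,5-dimethoxyphenyl in place of naphthalen-2-yl on an aromatic carbon. Among the compounds with values here, no measured step covers this change: the one aryl swap recorded, a step that the two limits leave unreadable from compound 1 to compound 2, cannot be sized because both ends are limits. With three of three values at the limit, compound 4 is expected to stay at the limit as well, and the step that the limit leaves unreadable from compound 3 to compound 4 is expected to be none beyond the scatter. The estimate for compound 4 in this assay is 35000 nM, within 15000 nM to 100000 nM.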

Compound 4, half-maximal effective concentration: > 26000 nM
Compound 4: a limit, no number; the forecaster's own chance of this, stated with the estimate: 85%; the middle value is on the limit's open side.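

Compound 4 gives > 26000 nM in this assay, a limit of the assay and not a number. Compound 3 also stands at a limit, so no step can be read from compound 3 to compound 4. The compounds shown leave open whether any aryl swap changes the read-out in this assay, since every value is a limit: the limit of > 26000 nM in this assay, at which 4 of the 4 values shown sit.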